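Biaryl series: sulfonamide to urea on the central ring

The source may hold more compounds than are shown below. What is called first, only, known or untested is meant among the compounds shown, and "the series" means these compounds.

Measured compounds in an assay on COS-7 cells for inhibition of patatin-like phospholipase domain-containing protein 2 (Mus musculus), tested at 200 uM; a higher number here means more inhibition at the concentration tested (going by the name of the read-out), a lower number less inhibition:
compound 1 `CCOC(=O)c1ccc(-c2ccc(OCC)cc2)s1` gives 81%
compound 2 `CCOC(=O)c1cccc(-c2ccc3c(c2)CCN3)c1` gives 66%
compound 3 `CCNS(=O)(=O)c1cccc(-c2ccc(OCC)cc2)c1` gives 46%

Compound 3 stands lowest of the three numbers in this assay. Its nearest neighbour is compound 2, whose reading lies higher by more than the scatter; compound 1 lies furthest away, higher again by more than the scatter. No pair among these three differs in only one place, so no single step between measured compounds can be read off, and the ranking rests on the three values alone.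

The next compound, compound 4 `CCOc1ccc(-c2cccc(NC(=O)N(C)C)c2)cc1`, keeps the biaryl of compound 3 and changes only the group on the aromatic carbon: (dimethylcarbamoyl)amino in place of ethylsulfamoyl on an aromatic carbon

Nothing measured here isolates this change, so the expected step in this assay is not anchored. The central biaryl with its ethoxy group is shared with compound 1, which gave the highest number, but the group that is exchanged is unrelated to that of compound 1, so no direction can be taken from it. The working expectation is a step from compound 3 to compound 4 of a number 4 percentage points higher from compound 3 to compound 4 (within the scatter), that is, none clearly beyond the scatter. For compound 4 the estimate in this assay is 50%, with a range from 25% to 75%.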

Compound 4, a percentage reported as inhibition, at one concentration (the size of the read-out at that concentration, not a potency): 68%
Beside the measured number, compound 4's estimate is 18 percentage points below it; low and high end bracket the measured number.
By their numbers in this assay, from the lowest: compound 3; then compounds 2 and 4 (each within the scatter of the next); then compound 1.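

In this assay, within the data shown here, the exchange of ethylsulfamoyl for (dimethylcarbamoyl)amino gives the first single-place step, a number 22 percentage points higher from compound 3 to compound 4 (beyond the scatter), so the group on this aromatic carbon, meta to a group of 9 heavy atoms, clearly bears on the reading. The heavy-atom count and the hydrogen-bond donor count stay the same across the exchange, while the hydrogen-bond acceptors and the double bonds outside aromatic rings become fewer, so the reading can move substantially with no change in the size of the group by that count. Nothing measured on these compounds bears on why the reading moves.

This is one pair at a single concentration, which leaves open how far the step carries over to other cores and how the two compounds compare in potency. Also open, as far as these compounds go, is what other groups on this aromatic carbon would give, such as a carboxylic acid, a primary amine or a urea with longer chains on its nitrogen in place of the two methyl groups.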